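This account rests on a few compounds, and the source may have more. Where it says the series, first, only, none or still open, it means among the compounds named here.

Compound 2 `C=CCn1nc(-c2cccnc2)c2ccccc2c1=O` gives 2140 nM in a functional assay (trachea) with Cavia porcellus as the target (on this read-out higher numbers stand for weaker inhibition and lower numbers for stronger inhibition), the lowest of the three numbers recorded; compound 1 `CCCCn1nc(-c2cccnc2)c2ccccc2c1=O` at 2290 nM lies within the scatter of it, as a 1.1-fold lower number from compound 1 to compound 2 (0.03 log units; within the scatter) shows, while compound 3 `COCCn1nc(-c2cccnc2)c2ccccc2c1=O` at 9330 nM sits further off, with a 4.4-fold higher number from compound 2 to compound 3 (0.64 log units; beyond the scatter). Compound 4 `O=c1c2ccccc2c(-c2cccnc2)nn1CCSc1nccs1` differs from compound 2 by ((1,3-thiazol-2-yl)sulfanyl)methyl in place of vinyl on a saturated chain carbon bound to an aromatic nitrogen. For the measured compounds named here, no measured step involves a group of this kind; the closest comparison is the modest step seen from compound 2 to compound 3, where a heteroatom-bearing group replaced the vinyl group at the same place. A modestly higher number is therefore expected, with wide uncertainty, so compound 4 is estimated at 4500 nM (range 1500 nM to 14000 nM), a step of a 2.1-fold higher number from compound 2 to compound 4 (0.32 log units; beyond the scatter).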

Compound 4, half-maximal inhibitory concentration: 10500 nM
For compound 4 the middle estimate is 2.3-fold (0.37 log units) below the measured one; the range from low to high includes it.
By their numbers in this assay, from the lowest: compounds 2 and 1 (each within the scatter of the next); then compounds 3 and 4 (each within the scatter of the next).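

In this assay, the much larger ((1,3-thiazol-2-yl)sulfanyl)methyl group still gives only a modest rise at this place (a 4.9-fold higher number from compound 2 to compound 4 (0.69 log units; beyond the scatter); a 4.6-fold higher number from compound 1 to compound 4 (0.66 log units; beyond the scatter)). It stands level with the methoxy chain (a 1.1-fold higher number from compound 3 to compound 4 (0.05 log units; within the scatter)), so among these compounds both chains with a heteroatom two bonds along from the aromatic nitrogen give higher numbers than the all-carbon chains, and the added ring brings no further step. No measurement here explains this. Going by these compounds, whether a methylsulfanyl or a terminal amine would give the same level stays open, so the shares of the sulfur and the thiazole ring remain unseparated.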